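Vero Cell Cytotoxicity Across Two Analogues and a Third

The source may hold more compounds than are shown below. What is called first, only, known or untested is meant among the compounds shown, and "the series" means these compounds.

compound 1 `CSc1ccc(C(=O)/C(=C/c2cccnc2)c2ccc(Cl)c(Cl)c2)cc1`: 88.6%
compound 2 `CCOC(=O)C(C(=O)c1ccc(OC)cc1)C(NC(C)=O)c1ccc(C(C)(C)C)cc1`: 89.5%

Both numbers come from an ADME assay on Vero cells (Chlorocebus sabaeus) for cytotoxicity, read by MTT assay, tested at 100 uM; on this read-out lower numbers stand for a stronger effect and higher numbers for a weaker effect at the one concentration tested. Of the two, compound 2 has the larger number, but its gap to compound 1 lies within the usual scatter, so the two compounds read alike. Compound 3 `CCOC(=O)C(C(=O)c1ccc(OC)cc1)C(NC(C)=O)c1cc(OC)ccc1Br` has not been measured. It differs from compound 2 in one place: 2-bromo-5-methoxyphenyl in place of 4-(tert-butyl)phenyl on a saturated chain carbon bound to an amide-type nitrogen and a saturated chain carbon. Within the data shown here, with no measured pair that changes this group, the step from compound 2 to compound 3 in this assay is expected to stay within the scatter, in no particular direction. Compound 3 is therefore estimated at 87%, with a range from 70% to 100%, a step of a number 2.5 percentage points lower from compound 2 to compound 3 (within the scatter).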

Compound 3, a percentage reported as activity, at one concentration (the size of the read-out at that concentration, not a potency): 90.7%
Compound 3: middle estimate off by 3.7 percentage points, on the low side; low and high end bracket the measured number.
By their numbers in this assay, from the lowest: compounds 1, 2 and 3 (each within the scatter of the next).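

Read in this assay and placed on a saturated chain carbon bound to an amide-type nitrogen and a saturated chain carbon, 2-bromo-5-methoxyphenyl in place of 4-(tert-butyl)phenyl gives a number 1.2 percentage points higher from compound 2 to compound 3 (within the scatter) and so reads alike. This position now has one measured change, and the two groups cannot be told apart at the single concentration tested. No available evidence bears on this result. The compounds shown leave open whether an amine, a carboxylic acid or a longer chain at this place would also read alike.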